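Ring nitrogen methyl versus hydrogen in two dibromopyrrole cores

The source may report more compounds than this note shows. Statements on the series, on what has been measured and on what is new or still open speak of the compounds shown alone.

Compound 1 `COc1ccc(OC)c(C(=O)/C=C/c2cc(Br)c(Br)n2C)c1` carries a methyl on the pyrrole nitrogen and an enone chain to a dimethoxyphenyl ring. In a functional assay on WRL68 cells (Homo sapiens) for cytotoxicity, read by MTT assay, with stated times of 6 h and 48 h (on this read-out lower numbers stand for stronger inhibition and higher numbers for weaker inhibition), compound 1 gives 3270 nM. Compound 2 `COc1ccc(OC)c(C(=O)/C=C/c2cc(Br)c(Br)[nH]2)c1` is its unmethylated counterpart, and in this assay compound 2 gives 12300 nM. The change hydrogen in place of methyl on an aromatic nitrogen thus produced a 3.8-fold higher number from compound 1 to compound 2 (0.58 log units; beyond the scatter), a weakening of the cytotoxic effect on this scale.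

Compound 3 `Cn1c(-c2cc(-c3ccc[nH]3)no2)cc(Br)c1Br` pairs the methylated dibromopyrrole with an isoxazole linked to a second pyrrole. The difference between the core of compound 3 and the core of compound 1 is not broken down here. In this assay compound 3 gives only a limit, >= 100000 nM, which is the limit of >= 100000 nM in this assay, at which 1 of the 3 values shown sits.

Compound 4 `Brc1cc(-c2cc(-c3ccc[nH]3)no2)[nH]c1Br` is not yet measured in this assay and arises from compound 3 by hydrogen in place of methyl on an aromatic nitrogen. The place line for this change reads the same, word for word, as that for compound 1 to compound 2, so it is the same change. Since that earlier change weakened the read-out, and compound 3 already sits at the limit, compound 4 is expected to remain at or beyond that limit, an expected step of a number no higher from compound 3 to compound 4 (the limit leaves the size open). The estimate for compound 4 in this assay is 100000 nM, spanning 50000 nM to 400000 nM, with the chief expectation that only a limit is reported.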

Compound 4, half-maximal inhibitory concentration: >= 100000 nM
Compound 4: a limit, no number (the forecaster's own chance of this, stated with the estimate: 85%); the middle value sits exactly at the limit.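

Compound 3 and compound 4 both give only a limit in this assay, so no step between them can be read, and the pair adds nothing to the series: the limit of >= 100000 nM in this assay, at which 2 of the 4 values shown sit.

The compounds shown leave open whether hydrogen in place of methyl on an aromatic nitrogen changes the read-out on the core of compound 3 as it does on the core of compound 1.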